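The source may hold more compounds than are shown below. What is called first, only, known or untested is meant among the compounds shown, and "the series" means these compounds.

Measured compounds:
compound 1, `CC(C)c1onc(-c2c(Cl)cccc2Cl)c1COc1ccc(N(C)C(=O)c2ccc(C(=O)O)cc2)c(C(F)(F)F)n1` — 63%
compound 2, `CC(C)c1onc(-c2c(Cl)cccc2Cl)c1COc1ccc(N(C)Cc2cccc(C(=O)O)c2)c(C(F)(F)F)n1` — 58%

In a functional assay on HEK293 cells for agonist activity at Bile acid receptor (Homo sapiens), read by a luciferase reporter (a lower number here means a smaller maximal response, a higher number a larger maximal response), compound 1 gives 63%. In the same assay compound 2 gives 58%. Among the compounds with values here, the only step among the measured compounds, a number 5 percentage points lower from compound 1 to compound 2 (within the scatter), shows that the two numbers sit within the usual scatter of each other, so neither can be placed above the other; compound 2 stands level with compound 1 on the evidence to hand.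

Compound 3, `CC(C)c1onc(-c2c(Cl)cccc2Cl)c1COc1ccc(N(C)Cc2ccc(OCCO)cc2)c(C(F)(F)F)n1`, is not yet measured. Its change from compound 2 is 4-(2-hydroxyethoxy)phenyl in place of 3-carboxyphenyl on a saturated chain carbon bound to a nitrogen on an aromatic ring. Within the data shown here, the one measured step, 3-carboxybenzyl in place of (4-carboxyphenyl)carbonyl on the nitrogen on the aromatic ring, touches the same part of the molecule and stayed within the scatter, but it kept a carboxylic acid in the group, whereas the 3-carboxyphenyl now leaves altogether. Among the measured compounds shown here, no measured pair shows what follows from removing that acid, so the expectation rests on the one neighbouring step alone. The step of a number 3 percentage points lower from compound 2 to compound 3 (within the scatter) is therefore expected to stay within the scatter, with the range widened for the untested change. Compound 3 is estimated at 55%, between 38% and 72%.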

Compound 3, largest response reached (reported as efficacy), in percent of the reference or control that the assay uses: 59%
The estimate for compound 3 lay 4 percentage points below the measured number; the measured number falls inside the stated range.
By their numbers in this assay, from the lowest: compounds 2, 3 and 1 (each within the scatter of the next).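

In this assay, 4-(2-hydroxyethoxy)phenyl in place of 3-carboxyphenyl on a saturated chain carbon bound to a nitrogen on an aromatic ring gives a number 1 percentage points higher from compound 2 to compound 3 (within the scatter), so this pair shows that the maximal response holds when the carboxylic acid leaves this group altogether, which the earlier step, with an acid on both sides, could not show. Set against the carbonyl-linked acid, 4-(2-hydroxyethoxy)benzyl in place of (4-carboxyphenyl)carbonyl on a nitrogen on an aromatic ring gives a number 4 percentage points lower from compound 1 to compound 3 (within the scatter), so all three groups on this nitrogen now stand level in this assay, with or without the acid. Nothing measured here accounts for this level response.

Every step among these compounds lies within the scatter, so they do not show which change on this nitrogen would move the maximal response at all. As far as these compounds go, it remains open how an amine or a longer chain in place of the 2-hydroxyethoxy group would read, and whether an unsubstituted benzyl would stand level with these three compounds.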